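Removing a ring chloro from a purine-like core

This account rests on a few compounds, and the source may have more. Where it says the series, first, only, none or still open, it means among the compounds named here.

Two measured compounds share a fused two-ring core carrying a benzyl group that bears a chloromethyl group. Compound 1 `ClCc1ccccc1Cn1cnc2c(Cl)ncnc21` has one chloro on the core, and compound 2 `ClCc1ccc(Cn2cnc3nc(Cl)nc(Cl)c32)cc1` carries two. In a functional assay on COLO 205 cells (Homo sapiens) for cytotoxicity, read by sulforhodamine B assay, with a stated time of 48 h (a lower number here means a stronger inhibitor of growth, a higher number a weaker inhibitor of growth), compound 2 gives 17400 nM, the highest of the two numbers, while compound 1 gives 3890 nM, a gap that lies beyond the usual scatter. The two compounds also differ in where the chloromethyl sits on the benzyl ring, so their comparison mixes two changes at once.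

Compound 3 `ClCc1ccc(Cn2cnc3ncnc(Cl)c32)cc1` keeps the benzyl group of compound 2 and changes only the core: hydrogen in place of chloro on an aromatic carbon. Among the measured compounds shown here, no measured pair isolates this single change. For the measured compounds named here, the only hint is that compound 1, which likewise has just one chloro on the core, gives 3890 nM, a lower number than compound 2. Compound 3 is therefore expected to give a lower number than compound 2, a step of a 2.2-fold lower number from compound 2 to compound 3 (0.34 log units; beyond the scatter), of moderate size. The estimate for compound 3 is 8000 nM, with a range from 2500 nM to 25000 nM.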

Compound 3, concentration for 50% growth inhibition: 1900 nM
Compound 3: the middle estimate sits 4.2-fold (0.62 log units) above what was measured; the measured number lies below the stated range.
By their numbers in this assay, from the lowest: compound 3; then compound 1; then compound 2.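

Among the compounds shown here, this is the first pair that isolates a single change: the chloro on the aromatic carbon between two ring nitrogen atoms gives way to hydrogen while the benzyl group stays as it is, and in this assay that change alone gives a 9.2-fold lower number from compound 2 to compound 3 (0.96 log units; beyond the scatter). Growth inhibition in these cells therefore does not depend on a chloro at this position, and in this pair the compound without it has the lower number. No measurement here explains the size or direction of this step, so its cause remains unknown.

Only chloro and hydrogen are shown at this position, so it remains open whether an amine, a methoxy group or a methyl group there would lower the number further or raise it again. Also open is what the remaining chloro on the core and the chloromethyl group contribute, since all the compounds shown carry both, and only a swap such as an amine for that chloro or a plain methyl for the chloromethyl group would test them.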